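The compounds below may be only part of what the source reports. "The series", "measured", "known", "first", "only" and "open" are said of these compounds alone.

Of the compounds shown here, three have so far been tested in a functional assay on LS174T cells (Homo sapiens) for inhibition, with a stated time of 4 days, tested at 1 uM; on this read-out lower numbers stand for a weaker effect and higher numbers for a stronger effect at the one concentration tested. Compound 1 `Fc1cccc(F)c1C#Cc1ccc(-n2cccc2)nc1` gives 80.5%. Compound 2 `Fc1cccc(F)c1C#Cc1cccc2[nH]ncc12` gives 19.8%, and compound 3 `Fc1cccc(F)c1C#Cc1ccnc2ccccc12` gives 15.4%. The number of compound 3 is the lowest of the three; its nearest neighbour is compound 2, whose number is higher by an amount within the scatter, while compound 1 lies higher by an amount beyond the scatter. Compound 4 `Fc1cccc(F)c1C#Cc1ccnc2cc(Cl)ccc12` has not yet been measured in this assay. It differs from compound 3 by chloro in place of hydrogen on an aromatic carbon. Within the data shown here, no step between measured compounds shows what such a change does here. The expected step is small, a number 4.6 percentage points higher from compound 3 to compound 4 (within the scatter), and not clearly beyond the scatter in either direction. Compound 4 is therefore expected to give about 20%, within a range from 5% to 45%.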

Compound 4, a percentage reported as inhibition, at one concentration (the size of the read-out at that concentration, not a potency): 36%
Estimate against measurement, compound 4: 16 percentage points below; low and high end bracket the measured number.
By their numbers in this assay, from the lowest: compounds 3 and 2 (each within the scatter of the next); then compound 4; then compound 1.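

In this assay, among these compounds, the first single change that can be read is chloro in place of hydrogen on this aromatic carbon, and it gives a number 20.6 percentage points higher from compound 3 to compound 4 (beyond the scatter). The position is therefore not indifferent to substitution: one chlorine atom on the six-membered aromatic ring of carbon only is enough to move the number beyond the scatter. Nothing available explains this step. Going by these compounds, it remains open whether fluoro, methoxy or an amine on the same carbon would give a similar step, and whether chloro would do the same on the other carbons of that ring.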